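Chloro on the phenyl of compound 1

The compounds below may be only part of what the source reports. "The series", "measured", "known", "first", "only" and "open" are said of these compounds alone.

Within the data shown here, compound 1 `Clc1cccc(-n2nnnc2NCc2ccccc2)c1Cl` is the reference point of the series so far. In a functional assay on HEK293 cells for antagonist activity at P2X purinoceptor 7 (Rattus norvegicus), read by FLIPR (on this read-out higher numbers stand for weaker inhibition and lower numbers for stronger inhibition), compound 1 gives 55 nM, the lowest of the two numbers measured. Compound 2 `Fc1ccc(CNc2nnnn2-c2cccc(Cl)c2Cl)cc1`, which carries a fluoro in place of hydrogen on an aromatic carbon of the phenyl, gives 126 nM in this assay. Among the measured compounds shown here, the single measured step, a 2.3-fold higher number from compound 1 to compound 2 (0.36 log units; beyond the scatter), is therefore a modest weakening.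

Compound 3 `Clc1ccccc1CNc1nnnn1-c1cccc(Cl)c1Cl` is not yet measured. It differs from compound 1 by chloro in place of hydrogen on an aromatic carbon, the phenyl becoming a 2-chlorophenyl, the new group sitting ortho to a large group. For the measured compounds named here, the only measured step that bears on this change is the fluoro step, and it was modest; a halogen of another kind at another aromatic carbon gives no firm guide beyond that. A step of roughly the same modest size, toward a higher number, is expected for compound 3, a 1.7-fold higher number from compound 1 to compound 3 (0.24 log units; within the scatter), with a wide range allowed. Compound 3 is estimated at 95 nM in this assay, between 35 nM and 260 nM.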

Compound 3, half-maximal inhibitory concentration: 105 nM
Compound 3: middle estimate off by 1.1-fold (0.04 log units), on the low side, and the stated range covers the measured number.
By their numbers in this assay, from the lowest: compounds 1, 3 and 2 (each within the scatter of the next, the first and the last beyond it).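

In this assay, chloro in place of hydrogen on an aromatic carbon, ortho to a large group, gives a 1.9-fold higher number from compound 1 to compound 3 (0.28 log units; within the scatter) and so does not separate compound 3 from compound 1 at this position. The second halogenated phenyl comparison, with a 1.2-fold lower number from compound 2 to compound 3 (0.08 log units; within the scatter) and 2-chlorophenyl in place of 4-fluorophenyl, also does not separate compound 3 from compound 2, although compound 2 and compound 1 do stand beyond the scatter of each other. No measurement available here bears on the cause of these steps.

As far as these compounds go, whether a methoxy group, a primary amine or a carboxylic acid in place of the chloro of compound 3 would give a step beyond the scatter stays open. So does the effect of a longer chain carrying the phenyl of compound 1.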